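Thiophen-2-yl for phenyl in a cytotoxicity series

This account rests on a few compounds, and the source may have more. Where it says the series, first, only, none or still open, it means among the compounds named here.

Of the compounds shown here, three have so far been measured in a functional assay on A-431 cells (Homo sapiens) for cytotoxicity, read by MTT assay, with a stated time of 48 h; on this read-out higher numbers stand for weaker inhibition and lower numbers for stronger inhibition. Compound 1 `CCCCCCCCNC(=O)[C@@H](NC(=O)c1ccccc1)[C@@H](C)O` gives 61300 nM in this assay, compound 2 `C/C=C/C=C/C(=O)N[C@H](C(=O)NCCCCCCCC)[C@@H](C)O` gives 58200 nM, and compound 3 `CCCCCCCCCCCCNC(=O)[C@@H](NC(=O)c1ccccc1)[C@@H](C)O` gives 41200 nM. Compound 3 thus has the lowest of the three numbers, though its gaps to both of the others are within the scatter. Two single-point steps link these compounds: one is a 1.5-fold lower number from compound 1 to compound 3 (0.17 log units; within the scatter), a lengthening of the chain on the amide nitrogen; the other is a 1.1-fold lower number from compound 1 to compound 2 (0.02 log units; within the scatter), an exchange of the group on the carbonyl carbon. Compound 4 `CCCCCCCCCCCCNC(=O)[C@@H](NC(=O)c1cccs1)[C@@H](C)O` differs from compound 3 in exactly one place: thiophen-2-yl in place of phenyl on a carbonyl carbon. Only the second of the measured steps bears on this change, since it also swaps the group on that carbonyl carbon, and it stayed within the scatter. On that basis no step beyond the scatter is expected in this assay, in either direction, the expected step being a 1.0-fold lower number from compound 3 to compound 4 (0.01 log units; within the scatter). Compound 4 is therefore estimated to give about 40000 nM in this assay, with a likely range from 20000 nM to 80000 nM.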

Compound 4, half-maximal inhibitory concentration: 16600 nM
Compound 4: middle estimate off by 2.4-fold (0.38 log units), on the high side; measured number below the stated range.
By their numbers in this assay, from the lowest: compound 4; then compounds 3, 2 and 1 (each within the scatter of the next).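

In this assay the place on a carbonyl carbon whose other neighbour is an amide-type nitrogen now shows a step beyond the scatter, as thiophen-2-yl in place of phenyl gives a 2.5-fold lower number from compound 3 to compound 4 (0.39 log units; beyond the scatter) and so a modest change. The earlier exchange on this carbonyl carbon, penta-1,3-dien-1-yl in place of phenyl, gave a 1.1-fold lower number from compound 1 to compound 2 (0.02 log units; within the scatter) and stayed within the scatter, so the group at this place can matter, though not every replacement of phenyl moves the number. No measured property of these groups is at hand to account for the step.

From the compounds shown here alone, whether thiophen-2-yl gives a step of this size on the shorter amide chain of compound 1 remains open. Also open, going by these compounds, is whether furan-2-yl, with oxygen in the ring, or pyridin-2-yl, with a ring nitrogen, would behave like thiophen-2-yl at this place.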